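Morpholine for pyrrolidine on a sulfonyl, a second time

The source may hold more compounds than are shown below. What is called first, only, known or untested is meant among the compounds shown, and "the series" means these compounds.

Three compounds share one core and differ in two places. Compound 3 `COc1cc(Cc2n[nH]c(=S)n2-c2ccccc2)c(S(=O)(=O)N2CCCC2)cc1OC` gives 2.13 in a physicochemical assay for lipophilicity; a lower number here means a more polar compound, a higher number a more lipophilic compound. Compound 1 `COc1cc(Cc2n[nH]c(=S)n2-c2ccccc2)c(S(=O)(=O)N2CCOCC2)cc1OC` differs from compound 3 by morpholin-4-yl in place of pyrrolidin-1-yl on a sulfonyl sulfur; in this assay compound 1 gives 1.57, a step of a number 0.56 log units lower from compound 3 to compound 1 (beyond the scatter). Compound 2 `COc1cc(Cc2n[nH]c(=S)n2-c2ccc(Cl)cc2)c(S(=O)(=O)N2CCCC2)cc1OC` differs from compound 3 by chloro in place of hydrogen on an aromatic carbon; in this assay compound 2 gives 2.11, and the step of a number 0.02 log units higher from compound 2 to compound 3 (within the scatter) stays within the scatter. Compound 4 `COc1cc(Cc2n[nH]c(=S)n2-c2ccc(Cl)cc2)c(S(=O)(=O)N2CCOCC2)cc1OC` is not yet measured; it differs from compound 2 by morpholin-4-yl in place of pyrrolidin-1-yl on a sulfonyl sulfur, the same change as from compound 3 to compound 1, made at the same place. Because the earlier step was a number 0.56 log units lower from compound 3 to compound 1 (beyond the scatter), compound 4 is expected to show a step of a number 0.56 log units lower from compound 2 to compound 4 (beyond the scatter) in this assay. The estimate for compound 4 is 1.55, expected to fall between 1.25 and 1.85.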

Compound 4, partition coefficient: 2.25
Compound 4: the middle estimate sits 0.70 log units below what was measured, outside the stated range (above it).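

In this assay, the same swap of pyrrolidin-1-yl for morpholin-4-yl gives a number 0.14 log units higher from compound 2 to compound 4 (within the scatter) on the chloro core, against a number 0.56 log units lower from compound 3 to compound 1 (beyond the scatter) on the core without chloro, so this change did not carry from one core to the other. The chloro change likewise depends on its partner: with morpholin-4-yl it gives a number 0.68 log units higher from compound 1 to compound 4 (beyond the scatter), with pyrrolidin-1-yl a number 0.02 log units higher from compound 2 to compound 3 (within the scatter). Two pairs cannot show which step is typical of the series, and nothing available accounts for the mismatch.

Still open, going by these compounds, is whether a bromo or methyl group in place of chloro would behave like chloro or like hydrogen. Also open, on these data alone, is how a piperidin-1-yl group on the sulfonyl sulfur would compare on each core.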